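A few compounds are considered here, and "the series" means these few. Any claim that something is new, unique, unknown or untested is made for them only; others in the source may bear on it.

Measured compounds:

- Compound 1 `Nc1ccc(Oc2ccccc2-c2ccc(S(=O)(=O)NCCNC(=O)Nc3ccc(Cl)cc3)s2)cc1`: > 50000 nM
- Compound 2 `COc1ccc(NC(=S)NCCNS(=O)(=O)c2sccc2-c2ccc(C)cc2Oc2ccc(O)c(O)c2)cc1`: 4100 nM
- Compound 3 `COc1ccc(Oc2ccccc2-c2ccsc2S(=O)(=O)N2CCN(C(=O)Nc3cccc([N+](=O)[O-])c3)CC2)cc1OC`: > 50000 nM

In a functional assay on HL-60 cells (Homo sapiens) for inhibition, read by CCK-8 assay, with a stated time of 48 h (a higher number here means a weaker inhibitor, a lower number a stronger inhibitor), compound 2 gives 4100 nM, the only finite half-maximal inhibitory concentration in the set. Compound 1 sits at > 50000 nM, which is a limit of the assay and not a number. Compound 3 likewise returns > 50000 nM, again a limit. Going by the values given here, compound 2 is therefore the one compound with a measurable number, and the other two stand at the limit of > 50000 nM in this assay, at which 2 of the 3 values shown sit.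

Compound 4 `COc1ccc(NC(=O)NCCNS(=O)(=O)c2sccc2-c2ccc(C)cc2Oc2ccc(O)c(O)c2)cc1` is not yet measured. It differs from compound 2 in one place: a group of 11 heavy atoms (8 carbon, 1 nitrogen, 2 oxygen; one six-membered aromatic ring of carbon only) in place of a group of 11 heavy atoms (8 carbon, 1 nitrogen, 1 oxygen, 1 sulfur; one six-membered aromatic ring of carbon only), on an amine nitrogen. Among the compounds with values here, no pair of measured compounds differs in a single place, so no measured step is available to anchor the expected size of this change. With compound 2 at 4100 nM as the only reference, the exchange at the amine nitrogen is expected to move the value little, if at all, with a slight drift toward weaker inhibition that may still fall within the scatter; the expected step is a 1.5-fold higher number from compound 2 to compound 4 (0.17 log units; within the scatter). Compound 4 is estimated at 6000 nM, with a range of 2000 nM to 20000 nM.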

Compound 4, half-maximal inhibitory concentration: 6100 nM
Compound 4: middle estimate off by 1.0-fold (0.01 log units), on the low side; the measured number falls inside the stated range.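

In this assay, a 1.5-fold higher number from compound 2 to compound 4 (0.17 log units; within the scatter) gives the series its first readable single-place step: on the amine nitrogen, (4-methoxyphenyl)carbamoyl takes the place of the sulfur-bearing group of equal heavy-atom count. Within the scatter, the two compounds cannot be told apart, so at this position oxygen in place of sulfur is tolerated and a finite number holds with either group. Nothing shown accounts for this outcome or gives any property of the two groups as measured.

On these data alone, whether a different kind of group on this amine nitrogen, such as a plain acetyl, a longer alkyl chain or a carboxylic acid, would shift the value remains open. Compound 1 and compound 3 differ from compound 2 in more than one place, so what separates their limits from the finite values cannot be assigned to any single part of the structure.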